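The source may report more compounds than this note shows. Statements on the series, on what has been measured and on what is new or still open speak of the compounds shown alone.

Compounds measured so far in an assay on microsomes for inhibition of acyl-CoA:cholesterol acyltransferase (Oryctolagus cuniculus); a higher number here means a weaker inhibitor, a lower number a stronger inhibitor:

Compound 1 `CC(C)c1cccc(C(C)C)c1NC(=O)NCC1(c2ccc(F)cc2)CCCC1`: 23 nM
Compound 2 `CC(C)c1cccc(C(C)C)c1NC(=O)NCC1(c2ccc(C(F)(F)F)cc2)CCCC1`: 66 nM

Among the compounds with values here, compound 2 stands at the higher of these two numbers, and the only step between them is a 2.9-fold higher number from compound 1 to compound 2 (0.46 log units; beyond the scatter). Compound 3 `CC(C)c1cccc(C(C)C)c1NC(=O)NCC1(c2ccc(C(=O)O)cc2)CCCC1` differs from compound 2 in one place: carboxy in place of trifluoromethyl on an aromatic carbon. That step swapped one small fluorine-bearing group for another; neither measured compound carries a carboxy group, so nothing measured here speaks directly to this change, and the expectation rests on the change itself with wide uncertainty. In this assay compound 3 is expected to give about 600 nM, within 80 nM to 5000 nM. The expected step is therefore a 9.1-fold higher number from compound 2 to compound 3 (0.96 log units; beyond the scatter), toward a weaker inhibitor.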

Compound 3, half-maximal inhibitory concentration: 3100 nM
For compound 3 the middle estimate is 5.2-fold (0.71 log units) below the measured one; the measured number falls inside the stated range.
By their numbers in this assay, from the lowest: compound 1; then compound 2; then compound 3.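

In this assay this position proves far more sensitive to its substituent than the two fluorine-bearing groups alone suggested: carboxy gives a 47-fold higher number from compound 2 to compound 3 (1.67 log units; beyond the scatter) and a 130-fold higher number from compound 1 to compound 3 (2.13 log units; beyond the scatter) as the inhibitor weakens. Those steps far exceed a 2.9-fold higher number from compound 1 to compound 2 (0.46 log units; beyond the scatter) between the fluorine-bearing groups. Unlike trifluoromethyl, carboxy brings a hydrogen-bond donor and acceptor, although that difference is only an observation here.

On these data alone, whether a methyl ester, a primary amide or an amine at this position would weaken inhibition as much remains open. Nothing measured here explains the size of this loss.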